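Replacing the Acrylamide Vinyl Group with a Branched Alkenyl Chain

The compounds below may be only part of what the source reports. "The series", "measured", "known", "first", "only" and "open" are said of these compounds alone.

Measured compounds:
- compound 1 `COc1cc(N(C)CCN(C)C)c(NC(=O)C=C(C)C)cc1Nc1nccc(-c2cn(C)c3ccccc23)n1`: 4100 nM
- compound 2 `C=CC(=O)Nc1cc(Nc2nc(C)cc(-c3cn(C)c4ccccc34)n2)c(OC)cc1N(C)CCN(C)C`: 2910 nM

Both compounds were tested in a functional assay on A549 cells (Homo sapiens) for antiproliferative activity, read by MTT assay, with a stated time of 72 h; a higher number here means a weaker inhibitor, a lower number a stronger inhibitor. Compound 2 holds the lower of the two numbers, but its gap to compound 1 is within the usual scatter of repeated measurements, so the two cannot be told apart on these data.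

Compound 3 `COc1cc(N(C)CCN(C)C)c(NC(=O)/C=C\C(C)C)cc1Nc1nc(C)cc(-c2cn(C)c3ccccc23)n1` differs from compound 2 in one place: 3-methylbut-1-en-1-yl in place of vinyl on a carbonyl carbon. The amide itself and the rest of the molecule stay the same; only the chain on the carbonyl carbon grows from two carbons to five, with a branch at its far end.

Among the compounds with values here, no measured pair shows exactly this change. Within the data shown here, the only guide is that compound 1, which also carries a larger substituted alkene on the same carbonyl, sits near compound 2. The expected step from compound 2 to compound 3 is therefore a small one toward a higher number, a 1.5-fold higher number from compound 2 to compound 3 (0.19 log units; within the scatter), possibly not beyond the scatter. Compound 3 is estimated at 4500 nM, with a likely range from 1800 nM to 11000 nM.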

Compound 3, half-maximal inhibitory concentration: 1070 nM
Beside the measured number, compound 3's estimate is 4.2-fold (0.62 log units) above it; the whole stated range lies above it.
By their numbers in this assay, from the lowest: compound 3; then compounds 2 and 1 (each within the scatter of the next).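

In this assay the change of vinyl to 3-methylbut-1-en-1-yl on a carbonyl carbon gives a 2.7-fold lower number from compound 2 to compound 3 (0.43 log units; beyond the scatter) and this modest step lies beyond the scatter. Within the data shown here, it is the first change in this set made in one place alone, and it shows that the chain on this amide carbonyl can grow from two carbons to five, with a branch at its far end, and still give a lower number. No measurement at hand accounts for this gain.

The compounds shown leave open whether the gain needs the far-end branch, which a straight pentenyl chain would test, or the double bond, which a saturated 3-methylbutyl chain would test. Also open, as far as these compounds go, is how a dimethylamino group at the end of the chain would fare here.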